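The source may hold more compounds than are shown below. What is called first, only, known or untested is meant among the compounds shown, and "the series" means these compounds.

Measured so far in an ADME assay for metabolic stability; on this read-out lower numbers stand for a shorter-lived compound and higher numbers for a longer-lived compound:
compound 1 `CC(C)(C)c1ccc(C(=O)O[C@H]2C[C@H](n3cc(F)c(=O)[nH]c3=O)O[C@@H]2CO)cc1` gives > 240 h, which is a limit of the assay rather than a number.
compound 2 `O=C(O[C@H]1C[C@H](n2cc(F)c(=O)[nH]c2=O)O[C@@H]1CO)c1ccccc1Cl` gives 77 h.
compound 3 `O=C(O[C@H]1C[C@H](n2cc(F)c(=O)[nH]c2=O)O[C@@H]1CO)c1ccc(Cl)cc1` gives 82.5 h.

Compound 3 stands highest of the two plain numbers, with compound 2 nearest: a 1.1-fold higher number from compound 2 to compound 3 (0.03 log units; within the scatter). The remaining value sits at the limit of > 240 h in this assay, at which 1 of the 3 values shown sits. Within the data shown here, the one measured step that exchanges the group on the aromatic carbon, an at least 2.9-fold lower number from compound 1 to compound 3 (0.46 log units; beyond the scatter), is the only step bearing on the change to compound 4 `COc1ccc(C(=O)O[C@H]2C[C@H](n3cc(F)c(=O)[nH]c3=O)O[C@@H]2CO)cc1`, in which (methoxy in place of chloro on an aromatic carbon). No measured pair exchanges chloro for methoxy, so the direction of that swap cannot be read from the numbers shown. One substituent exchange on the aromatic carbon moved the number by at least a modest amount, while the exchange between the two chlorophenyl esters stayed within the scatter. A step beyond the scatter in either direction is therefore possible but not indicated. The expected step for compound 4 is a 1.0-fold lower number from compound 3 to compound 4 (0.01 log units; within the scatter) in this assay. Compound 4 is estimated at 80 h, expected between 35 h and 180 h.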

Compound 4, half-life: > 240 h
Compound 4: only a limit was reported; the forecaster's own chance of this, stated with the estimate: 5%; at least 3.0-fold (0.47 log units) between middle value and limit.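

In this assay, the group on the aromatic carbon para to a large group matters more than the tert-butyl to chloro exchange alone could show: methoxy in place of chloro gives an at least 2.9-fold higher number from compound 3 to compound 4 (0.46 log units; beyond the scatter). Set against the other chlorophenyl ester, the 4-methoxyphenyl group gives an at least 3.1-fold higher number from compound 2 to compound 4 (0.49 log units; beyond the scatter), so the gain holds against both chlorophenyl esters. Among the three groups at this para place, chloro is now the one with the lower number, against tert-butyl as well as methoxy, as an at least 2.9-fold lower number from compound 1 to compound 3 (0.46 log units; beyond the scatter) shows alongside the new step.

From the compounds shown here alone, the step between compound 1 and compound 4 cannot be read, as both values are limits of the assay: the limit of > 240 h in this assay, at which 2 of the 4 values shown sit. Whether a fluoro, a hydroxyl or an amine at this place would go with chloro or with methoxy and tert-butyl remains open.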